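Swapping a Methoxy for a Fluoro on the Aryl Ring

The compounds below may be only part of what the source reports. "The series", "measured", "known", "first", "only" and "open" are said of these compounds alone.

Of the compounds shown here, three share one core and have been tested in an ADME assay on cells (Mus musculus, strain BALB/C) for cytotoxicity, read by MTT assay, with a stated time of 24 h; on this read-out higher numbers stand for lower toxicity in this test and lower numbers for higher toxicity in this test. Compound 1 `Cc1ccc(C(=O)N/N=C/c2ccccc2F)c(O)c1` carries a fluoro and gives 362000 nM. Compound 2 `Cc1ccc(C(=O)N/N=C/c2ccccc2)c(O)c1` lacks that fluoro and gives 578000 nM. Compound 3 `COc1cccc(/C=N/NC(=O)c2ccc(C)cc2O)c1` carries a methoxy instead and gives 672000 nM, the highest of the three numbers, though it sits within the scatter of both compound 2 and compound 1, so the three cannot be ranked against each other.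

Compound 4 `Cc1ccc(C(=O)N/N=C/c2cccc(F)c2)c(O)c1` is not yet measured. It differs from compound 3 in one place: fluoro in place of methoxy on an aromatic carbon, meta to a large group on the six-membered aromatic ring of carbon only.

Going by the values given here, two measured steps bear on this change. Removing a fluoro gave a 1.6-fold higher number from compound 1 to compound 2 (0.20 log units; within the scatter), and adding a methoxy gave a 1.2-fold higher number from compound 2 to compound 3 (0.07 log units; within the scatter). Both are within the scatter, so the data give no sign that either a fluoro or a methoxy on this ring moves the number in this assay by more than chance. The expected step is therefore a 1.3-fold lower number from compound 3 to compound 4 (0.13 log units; within the scatter), leaning if anything slightly downward, but nothing beyond the scatter is anticipated. Compound 4 is estimated at 500000 nM, within a range from 250000 nM to 1000000 nM.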

Compound 4, half-maximal cytotoxic concentration: 166000 nM
Compound 4: the middle estimate sits 3.0-fold (0.48 log units) above what was measured, and the stated range ends above it.
By their numbers in this assay, from the lowest: compound 4; then compounds 1, 2 and 3 (each within the scatter of the next).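

In this assay, this position on the ring proves able to shift the number beyond the scatter, which neither earlier step did: a fluoro in place of the methoxy gives (a 4.0-fold lower number from compound 3 to compound 4 (0.61 log units; beyond the scatter)), and a fluoro in place of hydrogen gives (a 3.5-fold lower number from compound 2 to compound 4 (0.54 log units; beyond the scatter)), both pointing to higher toxicity in this test. The fluoro of compound 1 sits elsewhere on the same ring, yet compound 1 at (362000 nM) and compound 4 at (166000 nM) lie within the scatter of each other, so these values do not show that the place of the fluoro matters. Nothing available explains why the fluoro in compound 4 lowers the number relative to hydrogen or methoxy.

Going by these compounds, with only hydrogen, methoxy and fluoro compared at this position, it remains open whether the shift is particular to fluoro or would also appear with another halogen such as chloro, or with a quite different group such as an amine or a carboxylic acid. On these data alone, it is also open whether a second fluoro on the same ring would lower the number further.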